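Cytotoxicity working notes: compound 2 to compound 3

A few compounds are considered here, and "the series" means these few. Any claim that something is new, unique, unknown or untested is made for them only; others in the source may bear on it.

Measured so far in an ADME assay on MT4 cells (Homo sapiens) for cytotoxicity, read by MTT assay; on this read-out higher numbers stand for lower toxicity in this test and lower numbers for higher toxicity in this test:
- compound 1 `Cc1cc(C)cc(S(=O)(=O)c2c(C(=O)NCC(=O)NC(C)c3ccccc3)[nH]c3ccc(Cl)cc23)c1`: 29400 nM
- compound 2 `Cc1cc(C)cc(S(=O)(=O)c2c(C(=O)NCc3cccc(F)c3F)[nH]c3ccc(Cl)cc23)c1`: > 51100 nM (a limit)

Compound 2 stands at the limit of > 51100 nM in this assay, at which 1 of the 2 values shown sits; this is a limit and not a number.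

The next compound to be read is compound 3 `Cc1cc(C)cc(S(=O)(=O)c2c(C(=O)NCC(=O)NCc3ccncc3)[nH]c3ccc(Cl)cc23)c1`. The change is ((pyridin-4-yl)methyl)carbamoyl in place of 2,3-difluorophenyl on a saturated chain carbon bound to an amide-type nitrogen. Cut one bond further out, this reads 2,3-difluorobenzyl to (((pyridin-4-yl)methyl)carbamoyl)methyl.

For the measured compounds named here, one measured step bears on this change: an at least 1.7-fold higher number from compound 1 to compound 2 (0.24 log units; that floor lies within the scatter). It also replaces a carbamoyl group with 2,3-difluorophenyl at that place, so the change to compound 3 runs the opposite way. Going by the values given here, its floor stays within the scatter, and no measured step shows the full size of the effect.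

In this assay, a modest move to a lower number is therefore expected, possibly none beyond the scatter, with compound 1 at 29400 nM as the nearest guide. The expected step is an at least 1.5-fold lower number from compound 2 to compound 3 (0.18 log units; that floor lies within the scatter). For compound 3 the estimate is 33000 nM, with an expected range of 12000 nM to 80000 nM.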

Compound 3, half-maximal cytotoxic concentration: > 48900 nM
Compound 3 gave a limit, no number; the forecaster's own chance of this, stated with the estimate: 30%; at least 1.4-fold (0.17 log units) between middle value and limit.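

In this assay compound 3 also ends in a limit and not a number: the limit of > 48900 nM in this assay, at which 1 of the 3 values shown sits. The place on a saturated chain carbon bound to an amide-type nitrogen therefore now carries two quite different groups that both end in limits, 2,3-difluorophenyl in compound 2 and ((pyridin-4-yl)methyl)carbamoyl in compound 3, so the step between these two compounds cannot be read. The closer comparison is on the amide-type nitrogen, where (pyridin-4-yl)methyl in place of 1-phenylethyl gives an at least 1.6-fold higher number from compound 1 to compound 3 (0.22 log units; that floor lies within the scatter), so the carbamoyl-bearing side chain of compound 1 and that of compound 3 are not separated beyond the usual scatter, and the value of compound 1 cannot be tied to the 1-phenylethyl group.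

Where compound 2 and compound 3 would give actual numbers in this assay stays open, since only limits stand for them. Also open, going by these compounds, is whether a carboxylic acid or a dimethylamino group in place of the pyridin-4-yl ring on this chain would give a number in this assay or another limit.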